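A few compounds are considered here, and "the series" means these few. Any claim that something is new, unique, unknown or untested is made for them only; others in the source may bear on it.

Measured compounds:
Compound 1 `O=C(Nc1ccc(-c2noc(-c3cccc(NS(=O)(=O)c4ccccc4)c3)n2)c(Cl)c1)c1cccnc1`. In a functional assay on MDA-MB-231 cells (Homo sapiens) for antiproliferative activity, read by MTT assay, with a stated time of 72 h (on this read-out higher numbers stand for weaker inhibition and lower numbers for stronger inhibition), compound 1 gives > 10000 nM, which is a limit of the assay rather than a number.
Compound 2 `O=C(Nc1ccc(-c2noc(-c3cccc(NS(=O)(=O)c4cccc(Cl)c4)c3)n2)c(Cl)c1)c1cccnc1`. In this assay compound 2 gives > 10000 nM, again a limit.
Compound 3 `O=C(Nc1ccc(Cl)cc1)Nc1cccc(-c2nc(-c3ccc(NC(=O)c4cccnc4)cc3Cl)no2)c1`. In this assay compound 3 gives > 10000 nM, also a limit.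

Compound 3 therefore stands where the whole set stands: the limit of > 10000 nM in this assay, at which 3 of the 3 values shown sit. None of the three steps can be sized, since both ends sit at the limit: a step that the two limits leave unreadable from compound 1 to compound 2, a step that the two limits leave unreadable from compound 1 to compound 3 and a step that the two limits leave unreadable from compound 2 to compound 3 all remain unreadable.

Compound 4 `Cc1ccc(NC(=O)Nc2cccc(-c3nc(-c4ccc(NC(=O)c5cccnc5)cc4Cl)no3)c2)cc1` is the next member. It differs from compound 3 by methyl in place of chloro on an aromatic carbon. Among the compounds with values here, no measured step touches this position, and the steps that do exist give no size, so nothing argues for a change beyond the scatter. The step from compound 3 to compound 4 is expected to be a step that the limit leaves unreadable from compound 3 to compound 4. Compound 4 is accordingly estimated at 15000 nM in this assay, with a range from 5000 nM to 40000 nM, and most probably the assay will again report only a limit for compound 4.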

Compound 4, half-maximal inhibitory concentration: 3500 nM
For compound 4 the middle estimate is 4.3-fold (0.63 log units) above the measured one; measured number outside the range, below it.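

In this assay, within the data shown here, the change from 4-chlorophenyl to 4-methylphenyl gives the first readable step, an at least 2.8-fold lower number from compound 3 to compound 4 (0.45 log units; beyond the scatter), so this position responds to the exchange of one chlorine for one carbon. Among these compounds, the (4-methylphenyl)carbamoyl group also separates compound 4 from the two phenylsulfonyl-type compounds, with an at least 2.8-fold lower number from compound 2 to compound 4 (0.45 log units; beyond the scatter) and an at least 2.8-fold lower number from compound 1 to compound 4 (0.45 log units; beyond the scatter), whereas all steps among the earlier compounds remained unreadable. Compound 4 is the only compound shown that gives a number rather than a limit: the limit of > 10000 nM in this assay, at which 3 of the 4 values shown sit.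

Each of these steps gives only a lower bound on its size, since its other end is a limit. As far as these compounds go, how an ethyl, a methoxy or an amine at this same position would compare with methyl remains open, as does whether a methyl on the ring of the sulfonyl compounds would also give a number.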